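The source may report more compounds than this note shows. Statements on the series, on what has been measured and on what is new or still open speak of the compounds shown alone.

Measured in a functional assay on MCF7 cells (Homo sapiens) for cytotoxicity, read by MTT assay, with a stated time of 48 h; on this read-out lower numbers stand for stronger inhibition and higher numbers for weaker inhibition:
- compound 1 `CCN(CC)C(=S)SC(CC(=O)c1ccccc1)c1ccc(Cl)cc1`: 120 nM
- compound 2 `CCN(CC)C(=S)SC(CC(=O)c1ccccc1)c1ccc(F)cc1`: 700 nM

Within the data shown here, compound 2 holds the higher of the two numbers, and the one measured step is a 5.8-fold higher number from compound 1 to compound 2 (0.77 log units; beyond the scatter). Compound 3 `CCN(CC)C(=S)SC(CC(=O)c1ccccc1)c1ccccc1OC` is unmeasured and differs from compound 2 as follows: 2-methoxyphenyl in place of 4-fluorophenyl on a saturated chain carbon bound to a saturated chain carbon and a sulfur. Among the measured compounds shown here, the measured step, fluoro in place of chloro on an aromatic carbon, bears only loosely on this change, and no measured compound carries 2-methoxyphenyl. No direction can be drawn from the data, so no change beyond the scatter is expected in this assay. The expected step is a 1.4-fold lower number from compound 2 to compound 3 (0.15 log units; within the scatter). For compound 3 the estimated value is 500 nM, with an expected range of 120 nM to 2000 nM.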

Compound 3, half-maximal inhibitory concentration: 16000 nM
Estimate against measurement, compound 3: 32-fold (1.51 log units) below, outside the stated range (above it).
By their numbers in this assay, from the lowest: compound 1; then compound 2; then compound 3.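

In this assay, the group on the saturated chain carbon bound to a saturated chain carbon and a sulfur tolerates the earlier halogen exchange with only a modest change, but 2-methoxyphenyl brings large steps: a 23-fold higher number from compound 2 to compound 3 (1.36 log units; beyond the scatter) and a 130-fold higher number from compound 1 to compound 3 (2.12 log units; beyond the scatter). The series thus shows that this position can strongly affect the read-out, with both halogenated compounds giving lower numbers than compound 3. No available evidence accounts for this result.

The compounds shown leave open how an unsubstituted phenyl or a dimethylamino-bearing phenyl would behave at this position.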